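Moving the halogen on the ring-nitrogen phenyl group

The compounds below may be only part of what the source reports. "The series", "measured", "known", "first", "only" and "open" are said of these compounds alone.

Compound 1 `O=C1N/C(=C\c2ccc(O)cc2)C(=O)N1c1ccc(I)cc1` is the starting point. Within the data shown here, in a functional assay on NCI-H292 cells (Homo sapiens) for antiproliferative activity (on this read-out higher numbers stand for weaker inhibition and lower numbers for stronger inhibition), compound 1 gives 25500 nM, and this is the only numerical value shown for any compound. Compound 2 `O=C1N/C(=C\c2ccc3ccccc3c2)C(=O)N1c1ccc(Cl)cc1` reaches only a limit of the assay in this assay, namely > 200000 nM (the limit of > 200000 nM in this assay, at which 1 of the 2 values shown sits). Compound 3 `O=C1N/C(=C\c2ccc(O)cc2)C(=O)N1c1cccc(Br)c1` has not yet been measured in this assay. It differs from compound 1 in a single place: 3-bromophenyl in place of 4-iodophenyl on an amide-type nitrogen in a ring. Among the measured compounds shown here, no step between two measured compounds that share this kind of change is available, so the expectation rests on compound 1 alone. The change is expected to give a step from compound 1 to compound 3 of a 1.6-fold higher number from compound 1 to compound 3 (0.20 log units; within the scatter), leaning toward weaker inhibition but not clearly beyond the usual scatter. Compound 3 is therefore expected to give about 40000 nM in this assay, with a range from 10000 nM to 160000 nM.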

Compound 3, half-maximal inhibitory concentration: > 200000 nM
Compound 3 gave a limit, no number (the forecaster's own chance of this, stated with the estimate: 25%); middle value at least 5.0-fold (0.69 log units) from the limit.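

On the amide-type nitrogen of the ring, the group is not freely exchangeable: in this assay, 3-bromophenyl in place of 4-iodophenyl gives an at least 7.8-fold higher number from compound 1 to compound 3 (0.89 log units; beyond the scatter), a step beyond the usual scatter, even though both groups hold the same count of heavy atoms. The inhibition that compound 1 shows therefore depends on which halogen-bearing phenyl group sits at this nitrogen. Compound 3 gives a limit of the assay and not a number, so the full size of this step cannot be read, and such limits now make up most of the results: the limit of > 200000 nM in this assay, at which 2 of the 3 values shown sit.

The halogen and its place on the ring change together in this one step, so the compounds shown do not separate the two. As far as these compounds go, how a plain phenyl group, or a phenyl group carrying an amine or a carboxylic acid, would behave at this nitrogen also remains open.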